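The compounds below may be only part of what the source reports. "The series", "measured", "known", "first", "only" and "open" are said of these compounds alone.

Measured compounds in a functional assay on HL-60 cells (Homo sapiens) for antiproliferative activity, read by MTT assay, with a stated time of 72 h; on this read-out higher numbers stand for weaker inhibition and lower numbers for stronger inhibition:
- compound 1 `CN(C(=O)C(C)(C)C)c1ccc2[nH]c(-c3n[nH]c4ccccc34)cc2n1`: 4990 nM
- compound 2 `CN(C(=O)c1ccc(Cl)cc1)c1ccc2[nH]c(-c3n[nH]c4ccccc34)cc2n1`: 450 nM
- compound 3 `CN(C(=O)c1ccc([N+](=O)[O-])cc1)c1ccc2[nH]c(-c3n[nH]c4ccccc34)cc2n1`: 6800 nM

Compound 3 gives the highest number of the three in this assay. Its nearest neighbour is compound 1, and the step of a 1.4-fold higher number from compound 1 to compound 3 (0.13 log units; within the scatter) lies within the scatter, so the two cannot be ordered. Its furthest neighbour is compound 2, reached by the step of a 15-fold higher number from compound 2 to compound 3 (1.18 log units; beyond the scatter).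

The next compound, compound 4 `CN(C(=O)c1ccco1)c1ccc2[nH]c(-c3n[nH]c4ccccc34)cc2n1`, differs from compound 3 in one place: furan-2-yl in place of 4-nitrophenyl on a carbonyl carbon.

For the measured compounds named here, two measured steps bear on this change. The step of an 11-fold lower number from compound 1 to compound 2 (1.04 log units; beyond the scatter) shows that an aromatic ring on the carbonyl carbon can bring the number far down from the tert-butyl amide, while a 15-fold higher number from compound 2 to compound 3 (1.18 log units; beyond the scatter) shows that the 4-nitrophenyl ring does not. Going by the values given here, no compound carries a five-membered heteroaromatic ring on the carbonyl carbon, so there is no direct precedent for furan-2-yl. The expectation is that removing the 4-nitrophenyl group takes the number below that of compound 3, toward the region of compound 1 and compound 2, with a wide range, expected as a 4.5-fold lower number from compound 3 to compound 4 (0.66 log units; beyond the scatter).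

Compound 4 is therefore estimated at 1500 nM in this assay, within 400 nM to 6000 nM.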

Compound 4, half-maximal inhibitory concentration: 4540 nM
Compound 4: middle estimate off by 3.0-fold (0.48 log units), on the low side, within the range that was stated.
By their numbers in this assay, from the lowest: compound 2; then compounds 4, 1 and 3 (each within the scatter of the next).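

In this assay, furan-2-yl on the carbonyl carbon cannot be told apart from 4-nitrophenyl, with a 1.5-fold lower number from compound 3 to compound 4 (0.18 log units; within the scatter), or from tert-butyl, with a 1.1-fold lower number from compound 1 to compound 4 (0.04 log units; within the scatter), so compounds 1, 3 and 4 now sit together despite carrying three different kinds of group at this place. Only 4-chlorophenyl separates from that group, with a 10-fold higher number from compound 2 to compound 4 (1.00 log units; beyond the scatter), which shows that an aromatic ring on the carbonyl carbon does not by itself bring the number down, whether it is a six-membered carbon ring or a five-membered ring with a hetero atom; among the four compounds, the low number belongs to compound 2 alone. No measurement at hand accounts for this separation of compound 2.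

The compounds shown leave open whether unsubstituted phenyl, 4-bromophenyl or 4-methoxyphenyl would join compound 2 or fall with the other three, which would tell whether the chloro group itself matters or only the absence of nitro. From the compounds shown here alone, it also remains open whether thiophen-2-yl would differ from furan-2-yl, and whether a saturated ring such as cyclohexyl would differ from tert-butyl.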